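Methyl on the thiophene ring of compound 1

The compounds below may be only part of what the source reports. "The series", "measured", "known", "first", "only" and "open" are said of these compounds alone.

Measured compounds:
compound 1 `C[C@H]1[C@H](NCc2cccs2)C[C@H]2C[C@@H]1C2(C)C` — 25000 nM
compound 2 `C[C@H]1[C@H](NCc2nccs2)C[C@H]2C[C@@H]1C2(C)C` — > 100000 nM

Going by the values given here, in an ADME assay on MDCK cells (Canis lupus familiaris) for cytotoxicity, read by microscopy, with a stated time of 48 h (on this read-out higher numbers stand for lower toxicity in this test and lower numbers for higher toxicity in this test), compound 1 gives 25000 nM, the only number measured; compound 2 `C[C@H]1[C@H](NCc2nccs2)C[C@H]2C[C@@H]1C2(C)C` reaches only a limit of the assay at > 100000 nM. Among the compounds with values here, the one measured step, an at least 4.0-fold higher number from compound 1 to compound 2 (0.60 log units; beyond the scatter), concerns 1,3-thiazol-2-yl in place of thiophen-2-yl and does not bear on the change to compound 3 `Cc1ccsc1CN[C@@H]1C[C@H]2C[C@@H]([C@H]1C)C2(C)C`, which is methyl in place of hydrogen on an aromatic carbon. Within the data shown here, no measured step therefore guides this change, and a step of no more than the scatter is expected, no change at the digits printed from compound 1 to compound 3 (within the scatter). Compound 3 is estimated at 25000 nM, within 10000 nM to 60000 nM.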

Compound 3, minimum cytotoxic concentration: 10000 nM
The estimate for compound 3 lay 2.5-fold (0.40 log units) above the measured number; low and high end bracket the measured number.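

In this assay, methyl on an aromatic carbon of the thiophene ring, next to the ring atom that bears a large group, gives a 2.5-fold lower number from compound 1 to compound 3 (0.40 log units; beyond the scatter), so this position responds to a single added carbon, with the number moving toward higher toxicity in this test. Measured against the thiazole analogue, the change reads an at least 10-fold lower number from compound 2 to compound 3 (1.00 log units; beyond the scatter). Compound 2 stands at a limit of the assay, not a number: the limit of > 100000 nM in this assay, at which 1 of the 3 values shown sits.

The compounds shown leave open whether ethyl, methoxy or chlorine on this same ring carbon would move the number the same way as methyl.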